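Diaryl urea series: removing one trifluoromethyl group

The source may hold more compounds than are shown below. What is called first, only, known or untested is meant among the compounds shown, and "the series" means these compounds.

Measured so far in a functional assay on DU-145 cells (Homo sapiens) for inhibition, read by sulforhodamine B assay, with a stated time of 48 h, tested at 10 uM; on this read-out higher numbers stand for a weaker effect at the one concentration tested and lower numbers for a stronger effect:
compound 1 `O=C(Nc1cccc(-n2cc(-c3ccncc3)c(-c3cc(O)cc(Cl)c3)n2)c1)Nc1ccc(Cl)c(Cl)c1`: -15.1%
compound 2 `COc1cc(Cl)cc(-c2nn(-c3cccc(NC(=O)Nc4ccc(Cl)c(C(F)(F)F)c4)c3)cc2-c2ccncc2)c1`: 15.2%
compound 3 `COc1cc(Cl)cc(-c2nn(-c3cccc(NC(=O)Nc4cc(C(F)(F)F)cc(C(F)(F)F)c4)c3)cc2-c2ccncc2)c1`: 13.1%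

Compound 3 stands second highest of the three numbers. Its nearest neighbour is compound 2, whose number lies a little higher, within the scatter, so the two cannot be ordered; the furthest is compound 1, whose number lies well lower, beyond the scatter. Compound 1 differs from compound 3 in more than one place, so nothing is said here about which change carries that gap.

The next compound, compound 4 `COc1cc(Cl)cc(-c2nn(-c3cccc(NC(=O)Nc4cccc(C(F)(F)F)c4)c3)cc2-c2ccncc2)c1`, differs from compound 3 in one place: hydrogen in place of trifluoromethyl on an aromatic carbon.

Among the measured compounds shown here, no pair of measured compounds differs by a single trifluoromethyl group, so the size of this step cannot be read from the series. Compounds 2 and 3 carry different groups on the same ring and give numbers within the scatter of each other, which suggests the ring tolerates such swaps without a large shift. The step of a number 4.9 percentage points higher from compound 3 to compound 4 (within the scatter) is therefore expected to be small, and no movement beyond the scatter is anticipated, with any drift more likely toward a weaker effect than a stronger one.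

For compound 4 the expected number in this assay is 18%, with a range from 0% to 38%.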

Compound 4, a percentage reported as activity, at one concentration (the size of the read-out at that concentration, not a potency): 15.9%
For compound 4 the middle estimate is 2.1 percentage points above the measured one; the range from low to high includes it.
By their numbers in this assay, from the lowest: compound 1; then compounds 3, 2 and 4 (each within the scatter of the next).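

In this assay, hydrogen in place of trifluoromethyl on an aromatic carbon gives a number 2.8 percentage points higher from compound 3 to compound 4 (within the scatter), and hydrogen in place of chloro on an aromatic carbon gives a number 0.7 percentage points higher from compound 2 to compound 4 (within the scatter). Among the compounds shown here, these are the first one-place readings, and neither step separates the compounds, so on this six-membered aromatic ring of carbon only, the trifluoromethyl group of compound 3 and the chloro group of compound 2 can each be replaced by hydrogen without a change that can be read in this assay at the one concentration tested. No measurement is available that would bear on the reason for this result.

From the compounds shown here alone, whether an amine or a carboxylic acid on the same aromatic carbon would give a step beyond the scatter remains open, as does whether these compounds would separate in a full potency measurement. Compound 1, at -15.1%, differs from the other compounds in more than one place, so which of its changes matters for its number also remains unresolved.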